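The source may report more compounds than this note shows. Statements on the series, on what has been measured and on what is new or still open speak of the compounds shown alone.

Compound 1 `CC(C(=O)NCc1ccc(C(F)(F)F)cc1N1CCC(Cc2ccccc2)(N(C)C)CC1)c1ccc(NS(C)(=O)=O)c(F)c1` — in an assay on CHO cells for displacement of a labelled ligand from transient receptor potential cation channel subfamily V member 1 (Homo sapiens), read by scintillation counting, with a stated time of 60 min (a higher number here means a weaker inhibitor, a lower number a stronger inhibitor), compound 1 gives 3.79 nM.
Compound 2 `CN(C)C1(Cc2ccccc2)CCN(c2cc(C(F)(F)F)ccc2CNC(=O)Nc2cccc3c2CC(O)CC3)CC1` — in this assay compound 2 gives 0.95 nM.

Compound 2 holds the lowest of the two numbers in this assay, with compound 1 standing a good way higher, beyond the scatter. Compound 3 `CN(C)C1(Cc2ccccc2)CCN(c2cc(C(F)(F)F)ccc2CNC(=O)Nc2ccc3cnccc3c2)CC1` carries isoquinolin-6-yl in place of 3-hydroxy-1,2,3,4-tetrahydronaphthalen-5-yl on an amide-type nitrogen. Going by the values given here, no measured pair shows this change, so its size is open. Since compound 2 gives 0.95 nM, compound 3 is expected to stay close to it, with a modest move toward a higher number of about a 2.1-fold higher number from compound 2 to compound 3 (0.32 log units; beyond the scatter). The value expected for compound 3 in this assay is 2 nM, within 0.5 nM to 8 nM.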

Compound 3, inhibition constant: 62 nM
The estimate for compound 3 lay 31-fold (1.49 log units) below the measured number, outside the stated range (above it).
By their numbers in this assay, from the lowest: compound 2; then compound 1; then compound 3.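

In this assay the group on this amide-type nitrogen proves far from interchangeable: isoquinolin-6-yl in place of 3-hydroxy-1,2,3,4-tetrahydronaphthalen-5-yl gives a 65-fold higher number from compound 2 to compound 3 (1.81 log units; beyond the scatter), a large step for two groups of similar size. The group that leaves carries a hydrogen-bond donor and the one that enters carries none, but the ring types change too, so this single step cannot separate the two differences. Nothing available explains the size of the step. From the compounds shown here alone, it remains open whether a plain 1,2,3,4-tetrahydronaphthalen-5-yl, without the hydroxy group, would keep the low number of compound 2, or whether a quinolin-6-yl would share the higher number of compound 3.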